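The compounds below may be only part of what the source reports. "The series", "measured", "known", "first", "only" and "open" are said of these compounds alone.

Working notes on the series.

All compounds share one core, shown for compound 1 `O=C(Nc1ccc(I)cc1)N[C@H]1CC[C@H](Oc2ccc(F)cc2)CC1`. In a functional assay on CRL2813 cells (Homo sapiens) for cytotoxicity, read by sulforhodamine B assay, with a stated time of 5 days (on this read-out higher numbers stand for weaker inhibition and lower numbers for stronger inhibition), compound 1 gives 10200 nM. Compound 2 `O=C(Nc1cccc(F)c1)N[C@H]1CC[C@H](Oc2ccc(F)cc2)CC1` gives 8300 nM in this assay, and the two values sit within the scatter of each other: a 1.2-fold lower number from compound 1 to compound 2 (0.09 log units; within the scatter). Compound 3 `O=C(Nc1ccccc1C(=O)O)N[C@H]1CC[C@@H](Oc2ccc(F)cc2)CC1` gives only a limit in this assay, > 20000 nM. On the numbers shown, compound 2 therefore cannot be told apart from compound 1, and compound 3 contributes no number to compare against.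

Compound 4 `Cc1cccc(NC(=O)N[C@H]2CC[C@H](Oc3ccc(F)cc3)CC2)c1` is not yet measured. It differs from compound 2 by methyl in place of fluoro on an aromatic carbon. Within the data shown here, the only measured step that bears on it is the exchange of one substituent on the same phenyl, a 1.2-fold lower number from compound 1 to compound 2 (0.09 log units; within the scatter), which stayed within the scatter. On that basis a step within the scatter, in no particular direction, is expected from compound 2 to compound 4 in this assay, a 1.0-fold higher number from compound 2 to compound 4 (0.01 log units; within the scatter). Compound 4 is expected to give about 8500 nM in this assay, with a range from 3500 nM to 20000 nM.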

Compound 4, half-maximal inhibitory concentration: 14400 nM
For compound 4 the middle estimate is 1.7-fold (0.23 log units) below the measured one, within the range that was stated.
By their numbers in this assay, from the lowest: compounds 2, 1 and 4 (each within the scatter of the next). At a limit, above all of these: compound 3.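

In this assay, methyl in place of fluoro on the aromatic carbon meta to a large group stays within the scatter, a 1.7-fold higher number from compound 2 to compound 4 (0.24 log units; within the scatter), so the two substituents cannot be told apart at this position. The comparison with the iodo compound also stays within the scatter, a 1.4-fold higher number from compound 1 to compound 4 (0.15 log units; within the scatter), and compounds 1, 2 and 4 form one set of values with no order among them. Until now, the measured phenyl substituents with numerical values were only halogens; compound 4 extends that set to a carbon substituent, with the number still not separable from theirs.

As far as these compounds go, whether an amine or a longer chain such as propyl at this position would move the number beyond the scatter remains open. Compound 3 gives only a limit and so adds no number to the comparison: the limit of > 20000 nM in this assay, at which 1 of the 4 values shown sits.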